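Swapping 3,4-dimethylphenyl for 4-iodophenyl on an amine nitrogen

The source may report more compounds than this note shows. Statements on the series, on what has been measured and on what is new or still open speak of the compounds shown alone.

Compound 1 (`CCOc1ccccc1NC1=CC(=O)c2nc3n(c2C1=O)[C@H]1OC[C@@H](O)[C@H]1OC3`) 2450 nM
Compound 2 (`Cc1ccc(NC2=CC(=O)c3nc4n(c3C2=O)[C@H]2OC[C@@H](O)[C@H]2OC4)cc1C`) 860 nM

Both values come from a functional assay on MGC-803 cells (Homo sapiens) for inhibition, read by sulforhodamine B assay (on this read-out lower numbers stand for stronger inhibition and higher numbers for weaker inhibition), and a lower number means stronger inhibition. Of these two compounds, compound 2 has the lowest number at 860 nM and compound 1 sits higher at 2450 nM on the same scale.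

Compound 3 (`O=C1C=C(Nc2ccc(I)cc2)C(=O)c2c1nc1n2[C@H]2OC[C@@H](O)[C@H]2OC1`) has not been measured yet. It carries 4-iodophenyl in place of 3,4-dimethylphenyl on an amine nitrogen and keeps the shared core unchanged.

For the measured compounds named here, only one measured step bears on this change, since it falls at the same amine nitrogen. Putting 3,4-dimethylphenyl in place of 2-ethoxyphenyl gave a 2.8-fold lower number from compound 1 to compound 2 (0.45 log units; beyond the scatter) and that step is modest. Going by the values given here, it shows that this group can move the number, but no measured compound carries iodine, so the direction remains uncertain. A modest step is expected in this assay and it leans upward, since compound 2 at 860 nM is the lower of just two values. The estimated step is a 1.4-fold higher number from compound 2 to compound 3 (0.14 log units; within the scatter) and it remains an expectation. Compound 3 is expected at 1200 nM with a range from 400 nM to 3500 nM in this estimate.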

Compound 3, half-maximal inhibitory concentration: 1400 nM
Beside the measured number, compound 3's estimate is 1.2-fold (0.07 log units) below it, and the stated range covers the measured number.
By their numbers in this assay, from the lowest: compounds 2, 3 and 1 (each within the scatter of the next, the first and the last beyond it).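

In this assay, putting 4-iodophenyl in place of 3,4-dimethylphenyl on the amine nitrogen gives a 1.6-fold higher number from compound 2 to compound 3 (0.21 log units; within the scatter) and so the two groups cannot be told apart on this read-out, even though one ring carries iodine and the other carries two methyl groups. Putting 4-iodophenyl in place of 2-ethoxyphenyl gives a 1.8-fold lower number from compound 1 to compound 3 (0.24 log units; within the scatter) as well, so compound 3 cannot be separated from either earlier compound, although those two stand apart by a 2.8-fold lower number from compound 1 to compound 2 (0.45 log units; beyond the scatter) and the three aryl groups therefore span only a narrow band of values. Nothing in the data shown gives a measured reason for these numbers.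

The compounds shown leave open whether a plain phenyl ring, a 4-methoxyphenyl ring or a 4-chlorophenyl ring on this nitrogen would stay in the same band, and whether a ring is needed there at all or a saturated group such as cyclohexyl would serve. They also leave open whether the gap between compound 1 and compound 2 follows from the ethoxy group itself or from its place on the ring, which a 4-ethoxyphenyl group could help to separate.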